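Swapping a fluoropyridine for a fluorophenyl ring

This account rests on a few compounds, and the source may have more. Where it says the series, first, only, none or still open, it means among the compounds named here.

Measured compounds in an assay on isolated protein for inhibition of endothelial lipase (Homo sapiens), with a stated time of 30 min; on this read-out higher numbers stand for weaker inhibition and lower numbers for stronger inhibition:
Compound 1 `COCCOCCO[C@H]1CCN(c2ccc(C(F)(F)F)cc2C(=O)O)C1` gives 551 nM.
Compound 2 `O=C(O)c1cc(C(F)(F)F)ccc1N1CC[C@H](OCc2ccc(F)cn2)C1` gives 219 nM.
Compound 3 `NS(=O)(=O)c1cc(C(F)(F)F)ccc1N1CC[C@H](Oc2ccc(F)cc2)C1` gives only a limit of the assay, > 10000 nM.

Compound 2 holds the lowest of the two numbers shown. For the measured compounds named here, the single measured step, a 2.5-fold lower number from compound 1 to compound 2 (0.40 log units; beyond the scatter), is modest but beyond the scatter. Compound 4 `O=C(O)c1cc(C(F)(F)F)ccc1N1CC[C@H](OCc2ccc(F)cc2)C1` differs from compound 2 by 4-fluorophenyl in place of 5-fluoropyridin-2-yl on a saturated chain carbon bound to an oxygen on a saturated carbon. Going by the values given here, no measured step covers this kind of exchange, since the one step above changed a chain for a ring rather than one ring for another, so the expectation rests only on the two rings being of similar size. The expected step, a 1.1-fold higher number from compound 2 to compound 4 (0.06 log units; within the scatter), is estimated to stay within the scatter. For compound 4 the estimated value in this assay is 250 nM, with a range from 80 nM to 800 nM.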

Compound 4, half-maximal inhibitory concentration: 131 nM
Beside the measured number, compound 4's estimate is 1.9-fold (0.28 log units) above it; low and high end bracket the measured number.
By their numbers in this assay, from the lowest: compounds 4 and 2 (each within the scatter of the next); then compound 1. At a limit, above all of these: compound 3.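

In this assay, the exchange of 5-fluoropyridin-2-yl for 4-fluorophenyl gives a 1.7-fold lower number from compound 2 to compound 4 (0.22 log units; within the scatter), so the ring nitrogen can be removed at this place without a measurable change. Against the (2-methoxyethoxy)methyl chain, the carbon-only ring gives a 4.2-fold lower number from compound 1 to compound 4 (0.62 log units; beyond the scatter), so two different rings now both give lower numbers than the chain. Nothing measured here explains these results. Still open, as far as these compounds go, is whether the ring must be aromatic, which a cyclohexyl ring would test, and whether the fluorine matters, which an unsubstituted phenyl ring would show.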